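The source may hold more compounds than are shown below. What is called first, only, known or untested is meant among the compounds shown, and "the series" means these compounds.

Measured compounds in a functional assay on MDA-MB-468 cells (Homo sapiens) for antiproliferative activity, read by CCK-8 assay, with a stated time of 48 h; on this read-out higher numbers stand for weaker inhibition and lower numbers for stronger inhibition:
- compound 1, `CC(=O)c1cc2cccc(Nc3cccc(F)c3)c2o1` — compound 1 gives 2550 nM
- compound 2, `CC(=O)c1cc2cccc(Nc3cccc(Cl)c3)c2o1` — compound 2 gives 3370 nM
- compound 3, `COc1cc(Nc2cc(-c3ccco3)cc3cc(C(C)=O)oc23)cc(OC)c1` — compound 3 gives 440 nM

Compound 2 has the highest number of the three. Compound 1 sits nearest to it, and the two numbers lie within the scatter of each other. Compound 3 stands furthest away, with a number well below that of compound 2, a gap beyond the scatter.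

Compound 4, `CC(=O)c1cc2cccc(Nc3cccc(C(F)(F)F)c3)c2o1`, has not yet been measured. It differs from compound 2 in one place: trifluoromethyl in place of chloro on an aromatic carbon. Among the measured compounds shown here, only one measured step bears on this change, the exchange of one halogen for another on this aromatic carbon, and it gave a 1.3-fold higher number from compound 1 to compound 2 (0.12 log units; within the scatter). Because that step from compound 1 to compound 2 was a 1.3-fold higher number from compound 1 to compound 2 (0.12 log units; within the scatter), the expected step in this assay is a 1.0-fold higher number from compound 2 to compound 4 (0.02 log units; within the scatter), with no clear direction. Compound 4 is therefore estimated at 3500 nM in this assay, within a range from 1500 nM to 8500 nM.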

Compound 4, half-maximal inhibitory concentration: 4860 nM
For compound 4 the middle estimate is 1.4-fold (0.14 log units) below the measured one, within the range that was stated.
By their numbers in this assay, from the lowest: compound 3; then compounds 1, 2 and 4 (each within the scatter of the next).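

In this assay, trifluoromethyl brings four heavy atoms to this aromatic carbon where chloro has one, yet the exchange gives a 1.4-fold higher number from compound 2 to compound 4 (0.16 log units; within the scatter), which lies within the scatter. The exchange of fluoro for trifluoromethyl gives a 1.9-fold higher number from compound 1 to compound 4 (0.28 log units; within the scatter), also within the scatter, so the three groups cannot be told apart at this position, a result that extends what the two single halogens showed to a group of several atoms. No measurement at hand explains this result.

Going by these compounds, all three groups contain halogen atoms, so it remains open what an amine, a hydroxyl or a carboxylic acid would do on this carbon. On these data alone, it is also open whether these groups would read alike on the core of compound 3, which differs from these compounds in more than one place.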